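This account rests on a few compounds, and the source may have more. Where it says the series, first, only, none or still open, it means among the compounds named here.

Compound 2, with the structure `CCn1c(C(=O)Nc2ccc(OC(F)(F)F)cc2)ccc1C(CC)(CC)c1ccc(OCCC(O)(CC)CC)c(C)c1`, is the starting point of this step. In an assay on cells for agonist activity at vitamin D3 receptor (Homo sapiens), with a stated time of 96 h (a higher number here means that more compound is needed for the effect, a lower number that less compound is needed), compound 2 gives > 10000 nM, which is a limit of the assay rather than a number. Among the compounds with values here, the only other measured compound, compound 1, has the structure `C=CCN(C)C(=O)c1ccc(C(CC)(CC)c2ccc(OCCC(O)(CC)CC)c(C)c2)n1CC`. In this assay compound 1 gives > 10000 nM, again a limit of the assay. Within the data shown here, the one measured step, a step that the two limits leave unreadable from compound 1 to compound 2, cannot be read in size, because the limit of > 10000 nM in this assay, at which 2 of the 2 values shown sit, leaves both values without a number.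

The unmeasured compound 3 has the structure `CCOC(=O)CN(C)C(=O)c1ccc(C(CC)(CC)c2ccc(OCCC(O)(CC)CC)c(C)c2)n1CC`. Against compound 2 the change is ((ethoxycarbonyl)methyl)(methyl)amino in place of (4-(trifluoromethoxy)phenyl)amino on a carbonyl carbon. No measured step bears on this exchange in a readable way, so nothing in the shown data points to a direction for the step in this assay, and the record so far consists only of limits.

Compound 3 is therefore expected to sit again at the limit, with an estimated value of 15000 nM, and a range from 5000 nM to 50000 nM. The expected step from compound 2 to compound 3 is a step that the limit leaves unreadable from compound 2 to compound 3.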

Compound 3, half-maximal effective concentration: 520 nM
For compound 3 the middle estimate is 29-fold (1.46 log units) above the measured one; the whole stated range lies above it.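

In this assay, the substituent on the amide nitrogen at this carbonyl carbon proves able to bring a compound off the limit, which the earlier pair could not show: ((ethoxycarbonyl)methyl)(methyl)amino in place of (4-(trifluoromethoxy)phenyl)amino gives an at least 19-fold lower number from compound 2 to compound 3 (1.28 log units; beyond the scatter). The smaller exchange of ethoxycarbonyl in place of vinyl on a saturated chain carbon bound to an amide-type nitrogen gives an at least 19-fold lower number from compound 1 to compound 3 (1.28 log units; beyond the scatter), so a change at the end of that chain is enough, with the methyl on the nitrogen and the rest of the shared core unchanged. Both sizes are only lower bounds, because each step starts from a compound without a number: the limit of > 10000 nM in this assay, at which 2 of the 3 values shown sit.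

From the compounds shown here alone, compound 3 gives 520 nM, and whether a carboxylic acid or a primary amide in place of ethoxycarbonyl, or a longer chain between that group and the amide-type nitrogen, would keep, improve or lose that value stays open. Also open, going by these compounds, is how far compound 1 and compound 2 actually lie from each other, as neither has a number in this assay.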